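The compounds below may be only part of what the source reports. "The series", "measured", "known", "first", "only" and "open" are said of these compounds alone.

Compound 1 `O=C(Nc1nc2ccc(Cl)cc2s1)c1cn(-c2ccccc2)nc1-c1ccccc1` and compound 2 `O=C(Nc1nc2ccc(Cl)cc2s1)c1cn(-c2ccccc2)nc1-c1ccc(F)cc1` share one core and differ only by fluoro in place of hydrogen on an aromatic carbon, placed on an aromatic carbon of a six-membered aromatic ring of carbon only, para to a large group. In a functional assay on PC-3 cells (Homo sapiens) for cytotoxicity, read by MTT assay, with a stated time of 72 h (on this read-out lower numbers stand for stronger inhibition and higher numbers for weaker inhibition), compound 1 gives 3690 nM and compound 2 gives 3170 nM, a step of a 1.2-fold lower number from compound 1 to compound 2 (0.07 log units; within the scatter). Compound 3 `COc1ccc(-c2nn(-c3ccccc3)cc2C(=O)Nc2nc3ccccc3s2)cc1` has a core whose difference from compound 1 is not broken down here; in this assay compound 3 gives 6670 nM. Compound 4 `COc1ccc(-c2nn(-c3ccccc3)cc2C(=O)Nc2nc3ccc(F)cc3s2)cc1` is related to compound 3 by fluoro in place of hydrogen on an aromatic carbon, the same kind of change, but here on an aromatic carbon of a ring that is part of a fused or bridged system of two rings, meta to a fused ring and para to a fused ring. Because a 1.2-fold lower number from compound 1 to compound 2 (0.07 log units; within the scatter) was small, a similarly small step is expected for a 1.2-fold lower number from compound 3 to compound 4 (0.08 log units; within the scatter), giving compound 4 an estimated 5500 nM in this assay.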

Compound 4, half-maximal inhibitory concentration: 4930 nM
Compound 4: the middle estimate sits 1.1-fold (0.05 log units) above what was measured; measured number inside the range.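

The new step in this assay is a 1.4-fold lower number from compound 3 to compound 4 (0.13 log units; within the scatter) and it agrees with the earlier one, taken on a different core: the same change on two cores in this assay, a 1.2-fold lower number (0.07 log units; within the scatter) from compound 1 to compound 2 and a 1.4-fold lower number (0.13 log units; within the scatter) from compound 3 to compound 4, 1.2-fold (0.07 log units) apart, within the scatter of two such steps

In these two pairs, then, fluoro in place of hydrogen on an aromatic carbon stays within the scatter on both cores, even though it sits on a different ring in each pair. For the compounds shown here, this shows only that the change did little in both places; it does not show that the same would hold on other cores or at other places on these rings. The compounds shown leave open what a different group, such as an amine, a nitrile or a carboxylic acid, would do at these same places.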